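Chain extension on a hydroxamate HDAC6 inhibitor

The source may report more compounds than this note shows. Statements on the series, on what has been measured and on what is new or still open speak of the compounds shown alone.

Measured compounds:
compound 1, `CS(=O)(=O)c1ccc(-n2ccc3cnc(Nc4cnn(CCCCCCC(=O)NO)c4)nc32)cc1`, 5.9 nM
compound 2, `O=C(CCCCCCn1cc(Nc2ncc3ccn(Cc4ccccc4F)c3n2)cn1)NO`, 8.4 nM
compound 3, `COc1cccc(Cn2ccc3cnc(Nc4cnn(CCCCCC(=O)NO)c4)nc32)c1`, 37.6 nM

In an assay on isolated protein for inhibition of protein deacetylase HDAC6 (Homo sapiens), with a stated time of 60 min (a lower number here means a stronger inhibitor, a higher number a weaker inhibitor), compound 3 gives the highest of the three numbers. Its nearest neighbour is compound 2, which gives 8.4 nM, and compound 1 gives 5.9 nM, both gaps beyond the scatter. For the measured compounds named here, the one measured step, a 1.4-fold higher number from compound 1 to compound 2 (0.15 log units; within the scatter), changes only the group on the aromatic nitrogen and is within the scatter, so the substituent on that nitrogen does not account for where compound 3 stands.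

Compound 4, `COc1cccc(Cn2ccc3cnc(Nc4cnn(CCCCCCC(=O)NO)c4)nc32)c1`, differs from compound 3 as follows: (hydroxycarbamoyl)methyl in place of hydroxycarbamoyl on a saturated chain carbon, five bonds along the chain from an aromatic nitrogen. With this change compound 4 carries the same chain to the hydroxamate as compounds 1 and 2. Going by the values given here, no measured step addresses this chain change directly, so the expectation rests on the observation that compounds 1 and 2, both bearing this longer chain, sit well below compound 3 despite different groups on the aromatic nitrogen. The step is therefore expected to be a 4.2-fold lower number from compound 3 to compound 4 (0.62 log units; beyond the scatter) in this assay, toward a lower number. Compound 4 is estimated at 9 nM, with a range from 4 nM to 22 nM.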

Compound 4, half-maximal inhibitory concentration: 28.8 nM
Beside the measured number, compound 4's estimate is 3.2-fold (0.51 log units) below it; the whole stated range lies below it.
By their numbers in this assay, from the lowest: compounds 1 and 2 (each within the scatter of the next); then compounds 4 and 3 (each within the scatter of the next).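

In this assay, for the compounds shown here, a 1.3-fold lower number from compound 3 to compound 4 (0.12 log units; within the scatter) lies within the scatter, so (hydroxycarbamoyl)methyl in place of hydroxycarbamoyl at this place on the chain gives no separation, a direct reading that the earlier compounds could not give. With the chain held the same, the group on the aromatic nitrogen now matters: 3-methoxyphenyl in place of 2-fluorophenyl on the saturated chain carbon gives a 3.4-fold higher number from compound 2 to compound 4 (0.54 log units; beyond the scatter) and 3-methoxybenzyl in place of 4-(methylsulfonyl)phenyl gives a 4.9-fold higher number from compound 1 to compound 4 (0.69 log units; beyond the scatter) as steps beyond the scatter, whereas a 1.4-fold higher number from compound 1 to compound 2 (0.15 log units; within the scatter) stayed within it. Among the compounds sharing the longer chain, the higher number goes with the 3-methoxybenzyl group.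

Still open, on these data alone, is whether a longer chain would shift the number, or whether an amine or a carboxylic acid in place of the methoxy group would do so. Nothing available gives a reason for these results.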